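Removing the chloro group from compound 3

The source may hold more compounds than are shown below. What is called first, only, known or untested is meant among the compounds shown, and "the series" means these compounds.

Measured compounds in a functional assay on KB cells (Homo sapiens) for cytotoxicity, read by MTT assay, with a stated time of 72 h; on this read-out higher numbers stand for weaker inhibition and lower numbers for stronger inhibition:
- Compound 1 `COc1ccccc1C(=O)NC(=S)NNc1ncnc2ccccc12`: compound 1 gives > 50000 nM, which is a limit of the assay and not a number.
- Compound 2 `O=C(NC(=S)NNc1ncnc2ccccc12)c1ccc(F)cc1`: compound 2 gives 1870 nM.
- Compound 3 `O=C(NC(=S)NNc1ncnc2ccccc12)c1ccccc1Cl`: compound 3 gives 7710 nM.

Of the two numbers shown, compound 3 stands highest, meaning the weaker of the two in this assay. Its nearest neighbour is compound 2, and between them lies a 4.1-fold higher number from compound 2 to compound 3 (0.62 log units; beyond the scatter). Compound 1 sits at the limit of > 50000 nM in this assay, at which 1 of the 3 values shown sits.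

Compound 4 `O=C(NC(=S)NNc1ncnc2ccccc12)c1ccccc1` has not yet been measured. It differs from compound 3 by hydrogen in place of chloro on an aromatic carbon; cut one bond further out, the change reads 2-chlorophenyl to phenyl. Among the compounds with values here, two measured steps bear on this part of the molecule. Chloro in place of methoxy gave an at least 6.4-fold lower number from compound 1 to compound 3 (0.81 log units; beyond the scatter), and 2-chlorophenyl in place of 4-fluorophenyl gave a 4.1-fold higher number from compound 2 to compound 3 (0.62 log units; beyond the scatter). Both steps are beyond the scatter, yet neither simply removes the group, so the size is clearer than the direction. A modest downward step, towards compound 2, is expected, estimated as a 1.9-fold lower number from compound 3 to compound 4 (0.28 log units; within the scatter). Compound 4 is therefore expected to give about 4000 nM in this assay, with a likely range from 1500 nM to 12000 nM.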

Compound 4, half-maximal inhibitory concentration: 2330 nM
For compound 4 the middle estimate is 1.7-fold (0.23 log units) above the measured one; low and high end bracket the measured number.
By their numbers in this assay, from the lowest: compounds 2 and 4 (each within the scatter of the next); then compound 3. At a limit, above all of these: compound 1.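

In this assay, within the data shown here, the plain phenyl ring of compound 4 gives this position a reference point that the earlier compounds lacked: removing the chloro group, which sits ortho to a large group, gives a 3.3-fold lower number from compound 3 to compound 4 (0.52 log units; beyond the scatter), so this substituent goes with a weaker result rather than a stronger one. Swapping the fluoro group for hydrogen gives a 1.2-fold higher number from compound 2 to compound 4 (0.10 log units; within the scatter), so in this assay the 4-fluorophenyl and phenyl compounds cannot be told apart. Replacing the methoxy group with hydrogen gives an at least 21-fold lower number from compound 1 to compound 4 (1.33 log units; beyond the scatter), and the size of this step is only a bound, as compound 1 gives a limit of the assay and not a number: the limit of > 50000 nM in this assay, at which 1 of the 4 values shown sits.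

The 2-chlorophenyl and 4-fluorophenyl groups differ in both the halogen and its place on the ring, so the compounds shown cannot separate the effect of the atom from that of its location, and a 4-chlorophenyl or 2-fluorophenyl group would be needed to do so. From the compounds shown here alone, how an amine, a carboxylic acid or a simple methyl group would behave on this ring also remains open.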